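Ring-bearing amides on the piperidine nitrogen of a GIP receptor series

The compounds below may be only part of what the source reports. "The series", "measured", "known", "first", "only" and "open" are said of these compounds alone.

Compound 1 `Cc1nc(S(C)(=O)=O)ccc1Oc1ncnc(OC2CCN(C(=O)OC(C)(C)C#N)CC2)c1F`: 1320 nM
Compound 2 `CCC1(OC(=O)N2CCC(Oc3ncnc(Oc4ccc(S(C)(=O)=O)nc4C)c3F)CC2)CC1`: 333 nM
Compound 3 `Cc1nc(S(C)(=O)=O)ccc1Oc1ncnc(OC2CCN(C(=S)OC(C)C)CC2)c1F`: 1050 nM

All three compounds were tested in a functional assay on isolated protein for inhibition of Glucose-dependent insulinotropic receptor (Rattus norvegicus), read by HTRF and cAMP accumulation; on this read-out lower numbers stand for an effect already at smaller amounts and higher numbers for an effect only at larger amounts of compound. Compound 3 gives 1050 nM, the second highest of the three numbers; its nearest neighbour is compound 1, and the two lie within the scatter, while compound 2 sits well apart with the lowest number of the set.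

Compound 4 `Cc1nc(S(C)(=O)=O)ccc1Oc1ncnc(OC2CCN(C(=O)C3CCCC3)CC2)c1F` has not yet been measured. It differs from compound 3 in one place: a group of 7 heavy atoms (6 carbon, 1 oxygen; one five-membered non-aromatic ring of carbon only) in place of a group of 6 heavy atoms (4 carbon, 1 oxygen, 1 sulfur; no ring), on an amine nitrogen in a ring. The groups on this nitrogen are the only variable in the set, so the two steps ending at compound 3 bear on the question. The step of a 1.3-fold lower number from compound 1 to compound 3 (0.10 log units; within the scatter) shows that swapping one chain-like group for another on this nitrogen changed little. The step of a 3.2-fold higher number from compound 2 to compound 3 (0.50 log units; beyond the scatter) shows that a group carrying a small carbon ring was markedly better than the chain-like group of compound 3. Since the cyclopentylcarbonyl group entering in compound 4 also carries a carbon ring, a step downward of moderate size is expected, a 2.1-fold lower number from compound 3 to compound 4 (0.32 log units; beyond the scatter), though the ring here is larger and sits directly on the carbonyl, so the estimate is uncertain. Compound 4 is thus expected to give about 500 nM, within 150 nM to 1600 nM.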

Compound 4, half-maximal effective concentration: 407 nM
Compound 4: the middle estimate sits 1.2-fold (0.09 log units) above what was measured; the range from low to high includes it.
By their numbers in this assay, from the lowest: compounds 2 and 4 (each within the scatter of the next); then compounds 3 and 1 (each within the scatter of the next).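

In this assay the cyclopentylcarbonyl group on the amine nitrogen gives a 2.6-fold lower number from compound 3 to compound 4 (0.41 log units; beyond the scatter) and also a 3.2-fold lower number from compound 1 to compound 4 (0.51 log units; beyond the scatter), so both of these steps to the new group lie beyond the scatter. Against the other ring-bearing group the picture is level, with a 1.2-fold higher number from compound 2 to compound 4 (0.09 log units; within the scatter), so a cyclopentyl group set directly on the carbonyl carbon does as well here as the 1-ethylcyclopropyl group held through an oxygen. All three earlier compounds carried an oxygen on that carbon, so only compound 4 shows that this oxygen is not required for a number in this range, and that among the four compounds the two with a carbon ring stand apart from the two without one.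

The data offer nothing that explains why the groups with a carbon ring give the lower numbers. From the compounds shown here alone, what a cyclohexyl or a phenyl group on this carbonyl carbon would give remains open, so it cannot yet be said whether the size of the ring matters at this position.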